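Methoxy on the cyclohexyl ring: a step into the unknown

This account rests on a few compounds, and the source may have more. Where it says the series, first, only, none or still open, it means among the compounds named here.

Three compounds share one core and differ only in the group on the carbonyl carbon. Compound 1 `CCC1=C(C(=O)OCC2CCCCC2)[C@H](c2ccc(O)c(Cl)c2)NC(=O)N1` carries a cyclohexylmethoxy group. In an ADME assay on cells (Homo sapiens) for cytotoxicity (a lower number here means that less compound is tolerated, a higher number that more compound is tolerated), compound 1 gives > 10000 nM, which is a limit of the assay rather than a number. Compound 2 `CCC1=C(C(=O)CCC2CCCCC2)[C@H](c2ccc(O)c(Cl)c2)NC(=O)N1` carries 2-cyclohexylethyl and in this assay gives > 10000 nM, again a limit. Compound 3 `CCC1=C(C(=O)CC2CCCCC2)[C@H](c2ccc(O)c(Cl)c2)NC(=O)N1` carries cyclohexylmethyl and gives > 10000 nM, also a limit. Because (the limit of > 10000 nM in this assay, at which 3 of the 3 values shown sit), the steps a step that the two limits leave unreadable from compound 1 to compound 2, a step that the two limits leave unreadable from compound 1 to compound 3 and a step that the two limits leave unreadable from compound 2 to compound 3 cannot be read in size. Compound 3 therefore stands at the same limit as the other two, with no number of its own.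

Compound 4 `CCC1=C(C(=O)CC2CCC(OC)CC2)[C@H](c2ccc(O)c(Cl)c2)NC(=O)N1` differs from compound 3 by methoxy in place of hydrogen on a saturated ring carbon. For the measured compounds named here, no measured step bears on this change with a readable size; all that is known is that three related compounds were tolerated up to the limit. The expected step that the limit leaves unreadable from compound 3 to compound 4 is estimated to be none beyond the scatter. Compound 4 is expected to give about 15000 nM, within 8000 nM to 30000 nM.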

Compound 4, half-maximal cytotoxic concentration: > 10000 nM
Compound 4 gave a limit, no number; the forecaster's own chance of this, stated with the estimate: 85%; the middle value is on the limit's open side.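

The steps from compound 1, compound 2 and compound 3 to compound 4 cannot be read in size, because in this assay all four compounds stand at one limit: the limit of > 10000 nM in this assay, at which 4 of the 4 values shown sit. Going by these compounds, how much of each compound is tolerated stays open, and so does whether methoxy in place of hydrogen changes that at all.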